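The source may report more compounds than this note shows. Statements on the series, on what has been measured and on what is new or still open speak of the compounds shown alone.

Compound 1 `CCc1nc(-c2ccc(Cl)cc2Cl)c(CC)nc1SC(C)CC` is the starting point of this note. Going by the values given here, in an assay on IMR-32 cells for displacement of a labelled ligand from corticotropin-releasing factor receptor 1 (Homo sapiens), read by scintillation counting, with a stated time of 2 h (on this read-out lower numbers stand for stronger inhibition and higher numbers for weaker inhibition), compound 1 gives 401 nM, the highest of the two numbers measured so far. Among the compounds with values here, compound 2 `CCc1nc(NC(CC)CC)c(OC)nc1-c1ccc(Cl)cc1Cl`, the only other measured member of the series, gives 5.9 nM in this assay; the gap between these two values lies well beyond the scatter, and compound 2 shows that much lower numbers are reachable on the shared core when a nitrogen-linked substituent sits on the ring carbon that carries the sulfur chain in compound 1.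

Compound 3 `CCCN(CCN(C)C)c1nc(CC)c(-c2ccc(Cl)cc2Cl)nc1CC` has not yet been measured. It differs from compound 1 in one place: (2-(dimethylamino)ethyl)(propyl)amino in place of (sec-butyl)sulfanyl on an aromatic carbon. Within the data shown here, no step between two measured compounds corresponds to this exact change, so the expectation rests on the two values above alone.

The step from compound 1 to compound 3 is expected to be a 6.7-fold lower number from compound 1 to compound 3 (0.82 log units; beyond the scatter), toward a lower number and beyond the scatter, in the direction that compound 2 with 5.9 nM points to. The estimate for compound 3 in this assay is 60 nM, with a range from 10 nM to 300 nM.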

Compound 3, inhibition constant: 1540 nM
Estimate against measurement, compound 3: 26-fold (1.41 log units) below, outside the stated range (above it).
By their numbers in this assay, from the lowest: compound 2; then compound 1; then compound 3.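

In this assay, going by these compounds alone, putting (2-(dimethylamino)ethyl)(propyl)amino in place of (sec-butyl)sulfanyl on this aromatic carbon gives a 3.8-fold higher number from compound 1 to compound 3 (0.58 log units; beyond the scatter) and so provides the first direct reading of a change at this position with the rest of the core of compound 1 held fixed. On this core, a nitrogen-linked chain at this carbon does not by itself lead to a lower number, and the earlier pair could not show this, since compound 2 differs from compound 1 in more than one place. The step still leaves the number within reach of that of compound 1 rather than abolishing binding in this assay, and no measurement at hand explains its direction or size.

The compounds shown do not separate the exchange of sulfur for nitrogen from the presence of the dimethylamino end of the chain, since both change together in this single step. A dipropylamino group on the same carbon of the core of compound 1 would divide these two parts of the change, while a morpholine ring there would test whether the nitrogen-linked substituent needs to be an open chain at all.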